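Rearranging the Trimethoxyphenyl Group in a Small Series

This account rests on a few compounds, and the source may have more. Where it says the series, first, only, none or still open, it means among the compounds named here.

Measured in a functional assay on MCF7 cells (Homo sapiens) for antiproliferative activity, read by sulforhodamine B assay, with a stated time of 48 h; a lower number here means a stronger inhibitor, a higher number a weaker inhibitor:

- compound 1 `COc1cccc(/C=C/C(=O)C(=Cc2ccc(F)cc2)C(=O)/C=C/c2cccc(OC)c2OC)c1OC`: 1830 nM
- compound 2 `COc1cc(C=C(C(=O)/C=C/c2cccc(OC)c2OC)C(=O)/C=C/c2cccc(OC)c2OC)ccc1O`: 480 nM
- compound 3 `COc1cccc(/C=C/C(=O)C(=Cc2cc(OC)c(OC)c(OC)c2)C(=O)/C=C/c2cccc(OC)c2OC)c1OC`: 840 nM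

Compound 3 gives 840 nM on this measure. The measured 1.8-fold higher number from compound 2 to compound 3 (0.24 log units; within the scatter) leaves it level with the 4-hydroxy-3-methoxyphenyl analogue, whereas a 2.2-fold lower number from compound 1 to compound 3 (0.34 log units; beyond the scatter) sets it clearly apart from the 4-fluorophenyl analogue.

Compound 4 `COc1cc(OC)c(C=C(C(=O)/C=C/c2cccc(OC)c2OC)C(=O)/C=C/c2cccc(OC)c2OC)c(OC)c1` has the same atoms joined differently (2,4,6-trimethoxyphenyl in place of 3,4,5-trimethoxyphenyl on a double-bonded chain carbon bound to a double-bonded chain carbon), with 2,4,6-trimethoxyphenyl in place of 3,4,5-trimethoxyphenyl on a double-bonded chain carbon bound to a double-bonded chain carbon.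

The measured steps all changed the group at this same place, and even a 3.8-fold lower number from compound 1 to compound 2 (0.58 log units; beyond the scatter) was only modest. None of them moves methoxy groups around the ring, so the data offer no direct guide to direction. No step beyond the scatter is therefore expected in this assay, and neither direction is favoured.

The estimated change is a 1.1-fold higher number from compound 3 to compound 4 (0.03 log units; within the scatter) and is expected to stay small.

Compound 4 is estimated at 900 nM, with an expected range from 350 nM to 2400 nM.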

Compound 4, half-maximal inhibitory concentration: 720 nM
Estimate against measurement, compound 4: 1.3-fold (0.10 log units) above; measured number inside the range.
By their numbers in this assay, from the lowest: compounds 2, 4 and 3 (each within the scatter of the next); then compound 1.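

In this assay, among the compounds shown here, rearranging the methoxy groups from 3,4,5-trimethoxyphenyl to 2,4,6-trimethoxyphenyl on a double-bonded chain carbon gives a 1.2-fold lower number from compound 3 to compound 4 (0.07 log units; within the scatter), so the first change of ring pattern alone at this place leaves the number level. The 2,4,6-trimethoxyphenyl group also stays level with the 4-hydroxy-3-methoxyphenyl group, with a 1.5-fold higher number from compound 2 to compound 4 (0.18 log units; within the scatter), while a 2.5-fold lower number from compound 1 to compound 4 (0.41 log units; beyond the scatter) sets it apart from the 4-fluorophenyl group, leaving compound 1 as the only one of the four separated from the rest. No measurement offered here accounts for this insensitivity to the methoxy pattern.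

The compounds shown leave open whether a dimethylamino group, a carboxylic acid or a longer alkoxy chain on the ring at this place would move the number beyond the scatter. They also leave open whether the level standing of compound 2, compound 3 and compound 4 would hold in other cell lines.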